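Piperazine amide series: capping group swap on compound 2

This account rests on a few compounds, and the source may have more. Where it says the series, first, only, none or still open, it means among the compounds named here.

Measured compounds in a functional assay (MiaPaCa cells, Homo sapiens) for inhibition, read by sulforhodamine B assay, with a stated time of 48 h; on this read-out higher numbers stand for weaker inhibition of growth and lower numbers for stronger inhibition of growth:
- compound 1 `O=C(CCN1C(=O)CSc2ccccc21)N1CCN(c2ccc([N+](=O)[O-])cc2)CC1` gives 68100 nM
- compound 2 `CC(C)(C)OC(=O)N1CCN(C(=O)CCN2C(=O)CSc3ccccc32)CC1` gives 51500 nM
- compound 3 `O=C(CCN1C(=O)CSc2ccccc21)N1CCC(Cc2ccccc2)CC1` gives 56800 nM

The three numbers sit close together. Compound 2 stands at the low end of them, yet the gap to compound 3 and the gap to compound 1 both fall inside the usual scatter, so no order among the three can be read from them. Within the data shown here, the only single-point step in the set is a 1.3-fold lower number from compound 1 to compound 2 (0.12 log units; within the scatter), which likewise changes nothing beyond the scatter.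

Compound 4 `O=C(CCN1C(=O)CSc2ccccc21)N1CCN(c2ccccc2)CC1` has not yet been measured in this assay. It differs from compound 2 by phenyl in place of tert-butoxycarbonyl on an amine nitrogen in a ring. Among the measured compounds shown here, the one step that bears on this change is the exchange of the same capping group in the step from compound 1 to compound 2 , where a 4-nitrophenyl and a tert-butoxycarbonyl gave numbers within the scatter of each other. A phenyl in the same place is therefore expected to leave the number where the series already sits, with a step of a 1.1-fold higher number from compound 2 to compound 4 (0.03 log units; within the scatter) that stays inside the scatter. The estimate for compound 4 in this assay is 55000 nM, with a range from 25000 nM to 120000 nM.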

Compound 4, concentration for 50% growth inhibition: > 100000 nM
Compound 4: only a limit was reported; the forecaster's own chance of this, stated with the estimate: 10%; middle value at least 1.8-fold (0.25 log units) away from the limit.
By their numbers in this assay, from the lowest: compounds 2, 3 and 1 (each within the scatter of the next). At a limit, above all of these: compound 4.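

Compound 4 is the only compound of the set reported as a limit of the assay rather than a number in this assay: the limit of > 100000 nM in this assay, at which 1 of the 4 values shown sits.

Its two new steps can be read only as floors: an at least 1.9-fold higher number from compound 2 to compound 4 (0.28 log units; that floor lies within the scatter) for phenyl in place of tert-butoxycarbonyl on an amine nitrogen in a ring, and an at least 1.4-fold higher number from compound 1 to compound 4 (0.16 log units; that floor lies within the scatter) for hydrogen in place of nitro on an aromatic carbon. Compounds 1, 2 and 3 left no sign that a change at this nitrogen could carry a reading to the limit, but neither floor passes the scatter, so a real shift is not yet shown for either change.

Going by these compounds, the true number for compound 4, and with it whether either step lies beyond the scatter, stays open, as does any cause for the reading. The compounds shown also do not tell how an acetyl or a benzyl on the same ring nitrogen, or an amine in place of the nitro on the aromatic carbon, would read.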